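Sulfanyl in place of oxy: one step to compound 4

The source may hold more compounds than are shown below. What is called first, only, known or untested is meant among the compounds shown, and "the series" means these compounds.

Measured so far:
compound 1 `Nc1cc(N)c2nc(-c3ccccc3)c(Oc3ccc(Cl)c(Cl)c3)nc2c1`: 14100 nM
compound 2 `Nc1cc(N)c2nc(-c3ccccc3)c(Oc3ccc(F)cc3)nc2c1`: 20400 nM
compound 3 `COc1cc(CNc2nc3cc(N)cc(N)c3nc2-c2ccccc2)cc(OC)c1OC`: 1550 nM

In a functional assay on MCF7 cells (Homo sapiens) for inhibition, read by sulforhodamine B assay, with a stated time of 48 h (on this read-out higher numbers stand for weaker inhibition of growth and lower numbers for stronger inhibition of growth), compound 1 stands second highest of the three numbers. Its nearest neighbour is compound 2, with a 1.4-fold higher number from compound 1 to compound 2 (0.16 log units; within the scatter). Furthest is compound 3, whose number lies beyond the scatter below that of compound 1.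

Compound 4 `Nc1cc(N)c2nc(-c3ccccc3)c(Sc3ccc(Cl)c(Cl)c3)nc2c1` is not yet measured. It differs from compound 1 in one place: (3,4-dichlorophenyl)sulfanyl in place of 3,4-dichlorophenoxy on an aromatic carbon.

For the measured compounds named here, no measured step touches this linking position; the only step recorded exchanges one aryl group for another on the oxygen and stays within the scatter. Nothing in the series points in either direction for the linker itself. Compound 4 is therefore expected to show no step beyond the scatter, estimated as a 1.0-fold lower number from compound 1 to compound 4 (0.00 log units; within the scatter). Compound 4 is estimated at 14000 nM, in a range from 5000 nM to 40000 nM.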

Compound 4, concentration for 50% growth inhibition: 5250 nM
Compound 4: middle estimate off by 2.7-fold (0.43 log units), on the high side; low and high end bracket the measured number.
By their numbers in this assay, from the lowest: compound 3; then compound 4; then compounds 1 and 2 (each within the scatter of the next).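

In this assay, for the compounds shown here, the linking atom itself counts: (3,4-dichlorophenyl)sulfanyl in place of 3,4-dichlorophenoxy gives a 2.7-fold lower number from compound 1 to compound 4 (0.43 log units; beyond the scatter) and so marks the first step beyond the scatter among the aryl-linked compounds, where the aryl exchange on oxygen alone did not leave it. Against compound 2, linker and aryl group change together, giving a 3.9-fold lower number from compound 2 to compound 4 (0.59 log units; beyond the scatter) with no way to split the two contributions. No supporting data bear on the reason for this step.

Open, from the compounds shown here alone, is whether the sulfanyl step carries over to the 4-fluorophenyl group. Also open, going by these compounds, is how a sulfonyl or a methylene link on this aromatic carbon would read.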